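Alkyl substituent series on a shared core, whole-organism inhibition

This account rests on a few compounds, and the source may have more. Where it says the series, first, only, none or still open, it means among the compounds named here.

Measured compounds:
compound 1 `Cc1ccn2c(C)c(C)nc2c1OCc1ccccc1`: 35%
compound 2 `Nc1cnc2c(OCc3ccccc3)cccn12`: 43%
compound 3 `CCc1nc2c(OCc3ccccc3)cccn2c1N`: 59%

In a functional assay on the whole organism with Canis familiaris (Canis lupus familiaris) as the target, at a dose of 8 mg/kg by the oral route (on this read-out lower numbers stand for a weaker effect and higher numbers for a stronger effect at the one dose given), compound 3 stands highest of the three measured values, with compound 2 its nearest neighbour and compound 1 the furthest; both gaps are beyond the scatter. Going by the values given here, compound 1 carries a different substitution pattern on the shared core and has no single-point step to the others, so only its value is noted.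

Among the compounds with values here, the one measured step of a single change, a number 16 percentage points higher from compound 2 to compound 3 (beyond the scatter), replaces hydrogen by ethyl on an aromatic carbon and gives a modest rise in this assay.

Compound 4 `CC(C)(C)c1nc2c(OCc3ccccc3)cccn2c1N` is not yet measured. It differs from compound 3 by tert-butyl in place of ethyl on an aromatic carbon, the same aromatic carbon of the five-membered aromatic ring that took the ethyl in the step from compound 2 to compound 3. Within the data shown here, that step bears on the present one, but it covers only the introduction of an alkyl group, not its further growth; no measured pair shows what a larger alkyl at this place does. The expected step for compound 4 is therefore a number 3 percentage points higher from compound 3 to compound 4 (within the scatter), a change estimated to stay within or only just beyond the scatter, leaning upward on the strength of the earlier rise. Compound 4 is expected to give 62% in this assay, estimated between 45% and 78%.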

Compound 4, a percentage reported as inhibition, in the whole organism at one dose (the size of the read-out at that dose, not a potency): 0%
For compound 4 the middle estimate is 62 percentage points above the measured one; measured number below the stated range.
By their numbers in this assay, from the lowest: compound 4; then compounds 1 and 2 (each within the scatter of the next); then compound 3.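

In this assay, the alkyl group at this aromatic carbon of the five-membered ring does not act in one direction: the rise seen with ethyl, a number 16 percentage points higher from compound 2 to compound 3 (beyond the scatter), does not carry over to tert-butyl. Tert-butyl in place of ethyl gives a number 59 percentage points lower from compound 3 to compound 4 (beyond the scatter), and tert-butyl in place of hydrogen gives a number 43 percentage points lower from compound 2 to compound 4 (beyond the scatter), so the change removes the gain from ethyl and also falls below the compound with hydrogen at this place, with compound 4 at 0%. Nothing available accounts for this reversal at the position, which for now stands as an observation on these three compounds only.

Still open, as far as these compounds go, is where between ethyl and tert-butyl the read-out turns, and whether branching or chain length governs it; an isopropyl group and a straight propyl chain on this same aromatic carbon would bear on that question. Each number also comes from one oral dose in this assay, so the compounds shown give no potency and do not show whether compound 4 would respond at a higher dose.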